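From 3-chlorophenyl to 4-cyanophenyl on a shared core

The source may report more compounds than this note shows. Statements on the series, on what has been measured and on what is new or still open speak of the compounds shown alone.

Compound 1 `C=CC(=O)N1C(=O)CC(c2ccccc2Cl)Sc2ccccc21` and compound 2 `C=CC(=O)N1C(=O)CC(c2cccs2)Sc2ccccc21` and compound 3 `C=CC(=O)N1C(=O)CC(c2cccc(Cl)c2)Sc2ccccc21` share one core. In a functional assay on MOLT-4 cells (Homo sapiens) for cytotoxicity, read by CCK-8 assay, with a stated time of 24 h (a higher number here means a weaker inhibitor, a lower number a stronger inhibitor), compound 3 gives 77500 nM and sits level with compound 1 at 80300 nM within the scatter, while compound 2 is the weakest at 557000 nM on that scale. Compound 4 `C=CC(=O)N1C(=O)CC(c2ccc(C#N)cc2)Sc2ccccc21` carries 4-cyanophenyl in place of 3-chlorophenyl on a saturated ring carbon and keeps the rest of the core. Among the measured compounds shown here, two measured steps bear on this. The step between the chlorophenyl groups is a 1.0-fold lower number from compound 1 to compound 3 (0.02 log units; within the scatter) while the step from thiophen-2-yl to 3-chlorophenyl is a 7.2-fold lower number from compound 2 to compound 3 (0.86 log units; beyond the scatter) and counts as modest. No nitrile has been measured yet. The expectation in this assay is a 1.4-fold higher number from compound 3 to compound 4 (0.15 log units; within the scatter) and thus no shift beyond the scatter. For compound 4 the estimate is 110000 nM with an expected range from 35000 nM at the low end to 350000 nM at the high end.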

Compound 4, half-maximal inhibitory concentration: 88700 nM
For compound 4 the middle estimate is 1.2-fold (0.09 log units) above the measured one, within the range that was stated.
By their numbers in this assay, from the lowest: compounds 3, 1 and 4 (each within the scatter of the next); then compound 2.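

In this assay, swapping a chlorine-bearing ring for a nitrile-bearing one changes little at this saturated ring carbon: a 1.1-fold higher number from compound 3 to compound 4 (0.06 log units; within the scatter) and a 1.1-fold higher number from compound 1 to compound 4 (0.04 log units; within the scatter) both stay within the scatter. The step from the thiophen-2-yl group, a 6.3-fold lower number from compound 2 to compound 4 (0.80 log units; beyond the scatter), is beyond the scatter, so 2-chlorophenyl, 3-chlorophenyl and 4-cyanophenyl now read alike and compound 2 alone stands apart. Nothing available here explains this pattern. Still open, as far as these compounds go, is whether a benzene ring bearing an amine or a carboxylic acid would stay level with these compounds or move clearly away from them.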